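Methylsulfanyl for methoxy on the benzyl ring of compound 1

A few compounds are considered here, and "the series" means these few. Any claim that something is new, unique, unknown or untested is made for them only; others in the source may bear on it.

Measured so far:
compound 1, `COc1ccc(CNc2nc([Se]C)nc3ccccc23)cc1`, > 100000 nM in an ADME assay on 184B5 cells (Homo sapiens) for cytotoxicity, read by MTT assay, with a stated time of 72 h; a lower number here means a stronger inhibitor of growth, a higher number a weaker inhibitor of growth
compound 2, `COc1ccc(CNc2nc([SeH])nc3ccccc23)cc1`, > 100000 nM
compound 3, `COc1ccc(CNc2nc(SC)nc3ccccc23)cc1`, > 100000 nM

The value given for compound 1 in this assay is a limit of the assay and not a number. The value for compound 2 is likewise a limit. The value for compound 3 is also a limit. All three therefore sit at the same point, (the limit of > 100000 nM in this assay, at which 3 of the 3 values shown sit), and none of the steps among them can be read: a step that the two limits leave unreadable from compound 1 to compound 2, a step that the two limits leave unreadable from compound 1 to compound 3 and a step that the two limits leave unreadable from compound 2 to compound 3 are all unreadable in size.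

Compound 4, `CSc1ccc(CNc2nc([Se]C)nc3ccccc23)cc1`, has not been measured in this assay. It differs from compound 1 by methylsulfanyl in place of methoxy on an aromatic carbon.

Going by the values given here, no measured step touches the same position of the core, so none of the three bears directly on this change. What the series does show is that three variations at the other end of the shared core all stay at the limit. The expectation for compound 4 is therefore that it also stays at the limit, with a step that the limit leaves unreadable from compound 1 to compound 4 that is not distinguishable from none; the estimated value for compound 4 is 150000 nM, expected to lie between 50000 nM and 500000 nM.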

Compound 4, concentration for total growth inhibition: > 100000 nM
Compound 4 was reported as a limit; the forecaster's own chance of this, stated with the estimate: 85%; the middle value does not contradict the limit.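

In this assay compound 4 gives > 100000 nM, which is a limit of the assay and not a number. Compound 1 also sits at a limit, so the step from compound 1 to compound 4 cannot be read. All the compounds shown sit at one point: the limit of > 100000 nM in this assay, at which 4 of the 4 values shown sit.

The compounds shown leave open whether any change on the shared core gives a value inside the range of this assay.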